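Benzylsulfonamide caffeic analogues: methoxy for trifluoromethyl

The compounds below may be only part of what the source reports. "The series", "measured", "known", "first", "only" and "open" are said of these compounds alone.

Of the compounds shown here, two have numbers so far. Compound 1 `O=S(=O)(/C=C/c1ccc(O)c(O)c1)NCCCCc1ccccc1` carries a four-carbon chain ending in a phenyl ring on the sulfonamide nitrogen; in a functional assay on BV-2 cells (Mus musculus) for inhibition, read by Griess assay, with stated times of 3 h and 24 h (a lower number here means a stronger inhibitor, a higher number a weaker inhibitor), compound 1 gives 23800 nM. Compound 2 `O=S(=O)(/C=C/c1ccc(O)c(O)c1)NCc1ccc(C(F)(F)F)cc1` carries a benzyl group bearing a trifluoromethyl instead; in this assay compound 2 gives 12600 nM. The two numbers sit close together, their gap lying within the usual scatter, so no order between compound 1 and compound 2 can be read from them.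

Compound 3 `COc1ccc(CNS(=O)(=O)/C=C/c2ccc(O)c(O)c2)cc1` is the next point. It differs from compound 2 in one place: methoxy in place of trifluoromethyl on an aromatic carbon. Going by the values given here, no measured pair shows this change, so nothing in the numbers so far tells what it does. Among the compounds with values here, with only two measured compounds, both giving similar numbers in this assay, the plain expectation is a step from compound 2 to compound 3 of a 1.2-fold higher number from compound 2 to compound 3 (0.08 log units; within the scatter), that is none beyond the scatter in either direction. On that basis compound 3 is estimated in this assay at 15000 nM, with a range from 6000 nM to 40000 nM.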

Compound 3, half-maximal inhibitory concentration: 26500 nM
Compound 3: the middle estimate sits 1.8-fold (0.25 log units) below what was measured; low and high end bracket the measured number.
By their numbers in this assay, from the lowest: compounds 2, 1 and 3 (each within the scatter of the next, the first and the last beyond it).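

Methoxy in place of trifluoromethyl on an aromatic carbon, para to a large group, gives a 2.1-fold higher number from compound 2 to compound 3 (0.32 log units; beyond the scatter) in this assay. Going by these compounds alone, this is the first sign that this position is not silent: the step is modest, but it lies beyond the scatter and favours trifluoromethyl over methoxy in this one pair. The change removes a group of four heavy atoms and brings in one of two heavy atoms that carries a hydrogen-bond acceptor, and with no measurement bearing on the result, a single step cannot show which of these differences, if either, matters.

The compounds shown leave open how other groups at this carbon would compare, such as a hydrogen, a chlorine, a nitrile or a carboxylic acid, and so whether trifluoromethyl and methoxy are points on any trend at all. Going by these compounds, it also remains open whether the same exchange gives a similar step on a longer chain, such as the four-carbon chain of compound 1, or only on the benzyl group.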